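The source may hold more compounds than are shown below. What is called first, only, known or untested is meant among the compounds shown, and "the series" means these compounds.

Measured in a functional assay on HeLa cells (Homo sapiens) for inhibition, read by MTT assay, with a stated time of 48 h; a lower number here means a stronger inhibitor of growth, a higher number a weaker inhibitor of growth:
- compound 1 `Cn1cc(C2CC(c3ccccc3)=NN2C(=O)c2cccnc2)c2ccccc21`: > 10000 nM
- compound 2 `COc1ccc(C(=O)N2N=C(c3ccccc3)CC2c2cn(C)c3ccccc23)cn1`: 3980 nM
- compound 3 `Cn1cc(C2CC(c3ccccc3)=NN2C(=O)c2cccnc2)c2cc(Br)ccc21`: 1730 nM

Compound 1 gives > 10000 nM, which is only a limit. Compound 3 has the lowest of the two true numbers, 1730 nM, while compound 2 gives 3980 nM.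

Compound 4 `COc1ccc(C2=NN(C(=O)c3cccnc3)C(c3cn(C)c4ccc(Br)cc34)C2)cc1` turns the phenyl of compound 3 into 4-methoxyphenyl: methoxy in place of hydrogen on an aromatic carbon. The closest guide is the step of an at least 2.5-fold lower number from compound 1 to compound 2 (0.40 log units; beyond the scatter), which also adds a methoxy in place of hydrogen, though at another place in the molecule. The step of an at least 5.7-fold lower number from compound 1 to compound 3 (0.76 log units; beyond the scatter) involves bromo, so it bears only loosely on this change. A modest fall in the number is therefore expected, a 1.7-fold lower number from compound 3 to compound 4 (0.24 log units; within the scatter). The estimated value for compound 4 is 1000 nM, with an expected range from 300 nM to 4000 nM.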

Compound 4, concentration for 50% growth inhibition: 890 nM
Estimate against measurement, compound 4: 1.1-fold (0.05 log units) above, and the stated range covers the measured number.
By their numbers in this assay, from the lowest: compounds 4 and 3 (each within the scatter of the next); then compound 2. At a limit, above all of these: compound 1.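

Changing the phenyl of compound 3 to 4-methoxyphenyl gives a 1.9-fold lower number from compound 3 to compound 4 (0.29 log units; within the scatter) in this assay, so a methoxy para to a large group on this ring leaves the number within the scatter of the number for compound 3. Methoxy had earlier been seen only at another place in the molecule, and the two steps cannot be ranked: the same change on two cores in this assay, an at least 2.5-fold lower number (0.40 log units; beyond the scatter) from compound 1 to compound 2 and a 1.9-fold lower number (0.29 log units; within the scatter) from compound 3 to compound 4; the limit leaves it open whether they differ

Still open, going by these compounds, is whether an amine or a longer chain such as ethoxy at this place would give a step beyond the scatter. Also open, on these data alone, is what this methoxy does on a core without the bromo.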